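A few compounds are considered here, and "the series" means these few. Any claim that something is new, unique, unknown or untested is made for them only; others in the source may bear on it.

Compound 1 `Nc1cc(-c2cc(Cl)cc3c2OC(C(=O)N2CCNCC2)C3)ccn1` gives 5600 nM in an assay on isolated protein for inhibition of ubiquitin carboxyl-terminal hydrolase 7 (Homo sapiens), read by fluorescence, with stated times of 30 min and 1 h (a higher number here means a weaker inhibitor, a lower number a stronger inhibitor), and stands at the highest of the two numbers measured; compound 2 `O=C([C@H]1Cc2cc(Cl)cc(-c3ccnc4cc(CO)sc34)c2O1)N1CCNCC1` gives 43 nM in this assay, far lower than compound 1 and beyond the scatter. Compound 3 `O=C(C1Cc2cc(Cl)cc(-c3ccnc4[nH]ccc34)c2O1)N1CCNCC1` has not been measured. It differs from compound 1 by a group of 9 heavy atoms (7 carbon, 2 nitrogen; one five-membered aromatic ring with 1 hetero atom, one six-membered aromatic ring with 1 hetero atom) in place of a group of 7 heavy atoms (5 carbon, 2 nitrogen; one six-membered aromatic ring with 1 hetero atom), on an aromatic carbon. Because compound 2 with its own two-ring group reaches 43 nM, a two-ring group on the same carbon of compound 3 is expected to lower the number, and the step of a 28-fold lower number from compound 1 to compound 3 (1.45 log units; beyond the scatter) is expected to lie beyond the scatter. Compound 3 is estimated at 200 nM, with a range from 40 nM to 1000 nM.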

Compound 3, half-maximal inhibitory concentration: 930 nM
Beside the measured number, compound 3's estimate is 4.7-fold (0.67 log units) below it; measured number inside the range.
By their numbers in this assay, from the lowest: compound 2; then compound 3; then compound 1.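

In this assay, the fused two-ring group in place of 2-aminopyridin-4-yl gives a 6.0-fold lower number from compound 1 to compound 3 (0.78 log units; beyond the scatter) on this aromatic carbon of the shared core. The step is modest, yet it shows that this carbon accepts a larger group with an added five-membered aromatic ring, even with fewer hydrogen-bond acceptors on that group. Nothing available here explains the step. Open, as far as these compounds go, is whether an aminomethyl group or a carboxylic acid on that five-membered ring would lower the number further. Also open, from the compounds shown here alone, is how a fluoro group in place of the chloro group would affect it.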